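A few compounds are considered here, and "the series" means these few. Any claim that something is new, unique, unknown or untested is made for them only; others in the source may bear on it.

Measured compounds in a functional assay on MCF7 cells (Homo sapiens) for inhibition, read by CCK-8 assay, with a stated time of 48 h; on this read-out lower numbers stand for stronger inhibition and higher numbers for weaker inhibition: compound 1 `COc1ccc(-c2cc3nccc(-c4cc(OC)c(OC)c(OC)c4)n3n2)cc1N` gives 27 nM; compound 2 `COc1cc(-c2ccnc3cc(-c4c[nH]c5ccccc45)nn23)cc(OC)c1OC` gives 85 nM; compound 3 `COc1cc(-c2ccnc3cc(-c4ccc5ccn(C)c5c4)nn23)cc(OC)c1OC` gives 74 nM.

Compound 3 stands second highest of the three numbers, close to compound 2, as a 1.1-fold lower number from compound 2 to compound 3 (0.06 log units; within the scatter) shows, and further from compound 1, as a 2.7-fold higher number from compound 1 to compound 3 (0.44 log units; beyond the scatter) shows. Compound 4 `COc1cc(-c2ccnc3cc(-c4cn(C)c5ccccc45)nn23)cc(OC)c1OC` differs from compound 3 by 1-methyl-1H-indol-3-yl in place of 1-methyl-1H-indol-6-yl on an aromatic carbon. The step that bears most on this change is a 1.1-fold lower number from compound 2 to compound 3 (0.06 log units; within the scatter), which moved the indolyl attachment point and stayed within the scatter. Among the measured compounds shown here, no measured step covers the methyl on the indole nitrogen alone. Compound 4 is therefore expected to land near compound 3, with a step of a 1.0-fold higher number from compound 3 to compound 4 (0.01 log units; within the scatter). The estimate for compound 4 in this assay is 75 nM, ranging from 35 nM to 160 nM.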

Compound 4, half-maximal inhibitory concentration: 95 nM
Compound 4: the middle estimate sits 1.3-fold (0.10 log units) below what was measured; measured number inside the range.
By their numbers in this assay, from the lowest: compound 1; then compounds 3, 2 and 4 (each within the scatter of the next).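

In this assay, 1-methyl-1H-indol-3-yl in place of 1-methyl-1H-indol-6-yl gives a 1.3-fold higher number from compound 3 to compound 4 (0.11 log units; within the scatter) and so does not separate the two attachment points. Methyl in place of hydrogen on an aromatic nitrogen, a change no earlier pair isolated, gives a 1.1-fold higher number from compound 2 to compound 4 (0.05 log units; within the scatter) and likewise separates nothing. The 3-amino-4-methoxyphenyl group of compound 1 still stands apart from this indole, with a 3.5-fold higher number from compound 1 to compound 4 (0.55 log units; beyond the scatter) beyond the scatter. On these data alone, whether a carboxylic acid or a longer chain on the indole would shift the number stays open. Nothing available here explains any of these steps.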